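Amino for hydrogen: two matched pairs in one growth assay

The source may hold more compounds than are shown below. What is called first, only, known or untested is meant among the compounds shown, and "the series" means these compounds.

Compound 1 `ClCc1ccc(Cn2cnc3c(Cl)ncnc32)cc1` and compound 3 `ClCc1ccccc1Cn1cnc2c(Cl)ncnc21` contain the same atoms joined differently; the difference between the two cores is not broken down here. In a functional assay on U-251 cells (Homo sapiens) for cytotoxicity, read by sulforhodamine B assay, with a stated time of 48 h (on this read-out higher numbers stand for weaker inhibition of growth and lower numbers for stronger inhibition of growth), compound 1 gives 1250 nM. In this assay compound 3 gives 2630 nM, a number beyond the scatter from compound 1 and within the scatter of compound 2.

Compound 2 `Nc1nc(Cl)c2ncn(Cc3ccc(CCl)cc3)c2n1` is compound 1 with the change (amino in place of hydrogen on an aromatic carbon). In this assay compound 2 gives 3550 nM. The step is a 2.8-fold higher number from compound 1 to compound 2 (0.45 log units; beyond the scatter), a modest weakening of growth inhibition on this single instance.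

Compound 4 `Nc1nc(Cl)c2ncn(Cc3ccccc3CCl)c2n1` stands to compound 3 as compound 2 stands to compound 1, carrying (amino in place of hydrogen on an aromatic carbon). The two place descriptions read the same word for word, so this is the same change, now made on the core of compound 3 rather than the core of compound 1. Among the compounds shown it occurs twice in all, only one of them measured.

The step expected from compound 3 to compound 4 in this assay is a 2.7-fold higher number from compound 3 to compound 4 (0.43 log units; beyond the scatter), resting on the one measured instance, because a 2.8-fold higher number from compound 1 to compound 2 (0.45 log units; beyond the scatter) is the sole guide and the two cores are related only as described above. Compound 4 is therefore estimated at 7000 nM in this assay. The range expected for compound 4 runs from 3000 nM to 17000 nM, wide since a single pair carries the whole expectation.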

Compound 4, concentration for 50% growth inhibition: 3470 nM
Estimate against measurement, compound 4: 2.0-fold (0.30 log units) above; the measured number falls inside the stated range.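

The amino group in place of hydrogen on the core of compound 3 gives, in this assay, a 1.3-fold higher number from compound 3 to compound 4 (0.12 log units; within the scatter), so this pair shows no separation between the two compounds, whereas the pair on the core of compound 1 does. Among these compounds, two pairs in a single cell line do not fix a common size for the change, and they do not show that it weakens growth inhibition on every core: only the step on the core of compound 1 lies beyond the scatter. Even so, the two instances cannot be told apart as different steps, so carrying the change from one core to the other is not contradicted, though its size on a further core remains poorly defined: the same change on two cores in this assay, a 2.8-fold higher number (0.45 log units; beyond the scatter) from compound 1 to compound 2 and a 1.3-fold higher number (0.12 log units; within the scatter) from compound 3 to compound 4, 2.2-fold (0.33 log units) apart, within the scatter of two such steps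

The compounds shown leave open whether any other group at the same aromatic carbon, such as a methylamino group, a hydroxyl group or a methoxy group, would behave as the amino group does on these two cores. They also leave open how the step would read with the chloromethyl group exchanged for a methyl group or a hydroxymethyl group, and whether the two cores would then still give steps that cannot be told apart.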